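A few compounds are considered here, and "the series" means these few. Any claim that something is new, unique, unknown or untested is made for them only; others in the source may bear on it.

Measured compounds:
- compound 1, `CC(C)c1ccc2nc(N)sc2c1`: > 10 mg/kg
- compound 2, `Cn1c(=N)sc2cc(OC(F)(F)F)ccc21`: 5 mg/kg

The series was tested in a functional assay on the whole organism with Rattus norvegicus as the target; a higher number here means that more compound is needed for the effect, a lower number that less compound is needed. Compound 1 gives > 10 mg/kg, which is a limit of the assay and not a number. Compound 1 therefore stands at the limit of > 10 mg/kg in this assay, at which 1 of the 2 values shown sits. For the measured compounds named here, compound 2 gives 5 mg/kg in this assay, and this is the only number among the two values shown; compound 2 is thus the one fixed point on the scale.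

Compound 3, `CSCCn1c(=N)sc2cc(OC(F)(F)F)ccc21`, has not yet been measured in this assay. It differs from compound 2 by (methylsulfanyl)methyl in place of hydrogen on a saturated chain carbon bound to an aromatic nitrogen; seen one bond further out, methyl becomes 2-(methylsulfanyl)ethyl. Going by the values given here, no measured step shows what such a change does, so the expectation can rest only on the value of compound 2.

The account therefore expects no step beyond the usual scatter, or at most a small one in either direction, from compound 2 to compound 3: no change at the digits printed from compound 2 to compound 3 (within the scatter). For compound 3 the estimate in this assay is 5 mg/kg, with a range from 2 mg/kg to 15 mg/kg.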

Compound 3, dose for half-maximal effect: 1 mg/kg
Compound 3: middle estimate off by 5.0-fold (0.70 log units), on the high side; the measured number lies below the stated range.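

In this assay, for the compounds shown here, the entry of (methylsulfanyl)methyl on the saturated chain carbon bound to an aromatic nitrogen gives a 5.0-fold lower number from compound 2 to compound 3 (0.70 log units; beyond the scatter), and this is the first measured step, since the earlier compounds differ in more than one place and offered no comparison. It shows that this place is open to change: turning methyl into 2-(methylsulfanyl)ethyl does not cost activity in the whole animal, and less compound is needed for the effect. Nothing shown explains why this change lowers the dose, and the one available observation about the series has no bearing on that question.

A single step cannot separate the contribution of the sulfur atom from that of the added chain length, and a plain propyl chain or a 2-methoxyethyl group would be needed to tell these two apart. On these data alone, it also remains open how far this place tolerates further change, for example a longer chain, or an amine or a carboxylic acid at the end of the chain.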